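This account rests on a few compounds, and the source may have more. Where it says the series, first, only, none or still open, it means among the compounds named here.

Measured so far in a functional assay on NCI-H1299 cells (Homo sapiens) for antiproliferative activity, read by XTT assay, with a stated time of 72 h; on this read-out higher numbers stand for weaker inhibition and lower numbers for stronger inhibition:
- compound 1 `COc1ccc(C(=O)/C=C/c2nc3ccccc3cc2-c2ccc(OC)cc2)cc1`: 6420 nM
- compound 2 `COc1ccc(-c2cc3ccccc3nc2/C=C/C(=O)c2ccc(OC)c(OC)c2)cc1`: 1050 nM

Compound 2 stands lowest of the two numbers in this assay, with compound 1 the nearest. Going by the values given here, the only step in hand is a 6.1-fold lower number from compound 1 to compound 2 (0.79 log units; beyond the scatter), which shows that a methoxy on an aromatic carbon is worth a modest change beyond the scatter. Compound 3 `COc1ccc(-c2cc3ccccc3nc2/C=C/C(=O)c2ccco2)cc1` carries furan-2-yl in place of 3,4-dimethoxyphenyl on a carbonyl carbon. This change removes both methoxy groups of compound 2 and exchanges the ring that bore them, so the step from compound 1 to compound 2 bears on it only in part: it indicates that losing a single methoxy already costs a modest amount, and compound 3 loses both together with the six-membered ring. A step to a higher number in this assay, at least as large as the methoxy step run in reverse, is therefore expected. The estimate for compound 3 is 8000 nM (range 2500 nM to 25000 nM), an expected step of a 7.6-fold higher number from compound 2 to compound 3 (0.88 log units; beyond the scatter).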

Compound 3, half-maximal inhibitory concentration: 730 nM
Compound 3: the middle estimate sits 11-fold (1.04 log units) above what was measured; measured number below the stated range.
By their numbers in this assay, from the lowest: compounds 3 and 2 (each within the scatter of the next); then compound 1.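

In this assay, on a carbonyl carbon whose other neighbour is the double-bonded chain carbon, furan-2-yl in place of 3,4-dimethoxyphenyl gives a 1.4-fold lower number from compound 2 to compound 3 (0.16 log units; within the scatter), so this exchange leaves the number within the scatter although both methoxy groups and the six-membered ring are gone. Against 4-methoxyphenyl at the same place, furan-2-yl gives an 8.8-fold lower number from compound 1 to compound 3 (0.94 log units; beyond the scatter), so the numbers here do not follow the methoxy count alone: compound 3 has none, yet compound 1, with one, is the compound that stands apart. No measurement at hand accounts for this result.

From the compounds shown here alone, whether an aromatic ring is needed at this place stays open, and a thiophene, a pyridine or a short alkyl chain on the carbonyl carbon would bear on that. Going by these compounds, the methoxyphenyl on the shared core is constant across compound 1, compound 2 and compound 3, so the effect of a hydroxyl or an amine there remains unknown.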